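This account rests on a few compounds, and the source may have more. Where it says the series, first, only, none or still open, it means among the compounds named here.

Compounds measured in a functional assay for antagonist activity at transient receptor potential cation channel subfamily V member 1 (Rattus norvegicus) (on this read-out lower numbers stand for stronger inhibition and higher numbers for weaker inhibition), so far:

- compound 1, `O=C(Nc1ccccc1)c1ccc(-c2ncccc2C(F)(F)F)cc1`: "not determined" (no result reported)
- compound 2, `N#Cc1ccc(NC(=O)c2ccc(-c3ncccc3C(F)(F)F)cc2)cc1`: 1300 nM
- compound 3, `CC(C)(C)c1ccc(NC(=O)c2ccc(-c3ncccc3F)cc2)cc1`: 1 nM

Of the two numbers in hand, compound 3 gives the lowest; compound 2 sits far higher, a gap well beyond the usual scatter. Compound 1 carries no number in this assay, so it gives no bearing on the comparison.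

Compound 4, `CCS(=O)(=O)Nc1cccnc1-c1ccc(C(=O)Nc2ccc(C(C)(C)C)cc2)cc1`, is the next compound to be measured. It differs from compound 3 in one place: (ethylsulfonyl)amino in place of fluoro on an aromatic carbon. Among the measured compounds shown here, no step between two measured compounds describes this kind of exchange, so the size of the change is an open question. With compound 3 already at the low end of what the assay reports, the more likely outcome is a modest move toward a higher number, and the step from compound 3 to compound 4 is expected to be a 10-fold higher number from compound 3 to compound 4 (1.00 log units; beyond the scatter). On that basis compound 4 is estimated at 10 nM in this assay, with a range from 1.5 nM to 80 nM.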

Compound 4, half-maximal inhibitory concentration: 4 nM
Beside the measured number, compound 4's estimate is 2.5-fold (0.40 log units) above it; the range from low to high includes it.
By their numbers in this assay, from the lowest: compound 3; then compound 4; then compound 2.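

In this assay, this aromatic carbon, ortho to a large group and two atoms from the ring nitrogen, takes (ethylsulfonyl)amino in place of fluoro with a 4.0-fold higher number from compound 3 to compound 4 (0.60 log units; beyond the scatter), a modest step though beyond the scatter. The earlier compounds shown here did not show that a single fluorine can give way here to a group of six heavy atoms, carrying a hydrogen-bond donor and acceptors, while compound 4 still reads 4 nM on this measure. Nothing measured here accounts for the size of this step.

With only these two groups compared at this position, the compounds shown leave open how a plain amine, a methylsulfonylamino group or a longer chain on the sulfonyl would read. They also leave open whether the sulfonyl unit itself or simply the larger group sets the result.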